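Methyl for Hydrogen on an Oxygen, Tried Twice

The source may hold more compounds than are shown below. What is called first, only, known or untested is meant among the compounds shown, and "the series" means these compounds.

Compound 1 `C/C(COc1ccc2c(=O)cc(-c3ccccc3)oc2c1)=N\O` and compound 2 `CO/N=C(\C)COc1ccc2c(=O)cc(-c3ccccc3)oc2c1` differ in one place: methyl in place of hydrogen on an oxygen. In a functional assay on SK-HEP1 cells (Homo sapiens) for antiproliferative activity (a lower number here means a stronger inhibitor of growth, a higher number a weaker inhibitor of growth), compound 1 gives 2800000 nM, and compound 2 gives 2000000 nM; the step of a 1.4-fold lower number from compound 1 to compound 2 (0.15 log units; within the scatter) is small. Compound 3 `O=c1cc(-c2ccccc2)oc2ccc(OC/C(=N/O)c3ccccc3)cc12` is built on a different core; the difference between the two cores is not broken down here. In this assay compound 3 gives 700000 nM, the lowest of the three numbers. Compound 4 `CO/N=C(/COc1ccc2oc(-c3ccccc3)cc(=O)c2c1)c1ccccc1` has not yet been measured and differs from compound 3 by methyl in place of hydrogen on an oxygen, the same change as between compound 1 and compound 2, at the same place. A similar small step is expected, a 1.4-fold lower number from compound 3 to compound 4 (0.15 log units; within the scatter), because the earlier step of a 1.4-fold lower number from compound 1 to compound 2 (0.15 log units; within the scatter) stayed within the scatter. Compound 4 is therefore estimated to give 500000 nM in this assay, with a likely range from 200000 nM to 1500000 nM.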

Compound 4, concentration for 50% growth inhibition: 8200000 nM
The estimate for compound 4 lay 16-fold (1.21 log units) below the measured number; the measured number lies above the stated range.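

In this assay, putting methyl in place of hydrogen on the oxygen gives a 12-fold higher number from compound 3 to compound 4 (1.07 log units; beyond the scatter) and so does not repeat the small step seen on the core of compound 1. The size of this change therefore did not carry from one core to the other in this series: the same change on two cores in this assay, a 1.4-fold lower number (0.15 log units; within the scatter) from compound 1 to compound 2 and a 12-fold higher number (1.07 log units; beyond the scatter) from compound 3 to compound 4, 16-fold (1.21 log units) apart, beyond the scatter of two such steps

This shows that a step measured on one of these cores is a poor guide to the same step on the other. For the compounds shown here, it does not show which difference between the cores matters, and with only two pairs it cannot show which step is the more typical. The compounds shown leave open how an ethyl group or a longer chain on the same oxygen would behave on each core. They also leave open whether a carboxylic acid at the end of such a chain would follow either step.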